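Swapping Methylsulfonyl for Methylsulfanyl on Compound 1

A few compounds are considered here, and "the series" means these few. Any claim that something is new, unique, unknown or untested is made for them only; others in the source may bear on it.

Compound 1 `COc1ccc(S(C)(=O)=O)c(NCC2=NCCN2)c1` was tested in a functional assay for agonist activity at Alpha-1A adrenergic receptor (Homo sapiens) (a higher number here means that more compound is needed for the effect, a lower number that less compound is needed), where compound 1 gives 14.1 nM. Among the measured compounds shown here, of the three numbers measured so far this is the lowest, although compound 2 `CS(=O)(=O)c1ccc(F)cc1NCC1=NCCN1` sits close: in this assay compound 2 gives 16.6 nM, and the step of a 1.2-fold higher number from compound 1 to compound 2 (0.07 log units; within the scatter) is within the scatter, so the two cannot be separated. Compound 3 `CC(C)S(=O)(=O)c1ccccc1NCC1=NCCN1` lies far away; in this assay compound 3 gives 1950 nM. Compound 3 differs from compound 1 in more than one place, so its large gap cannot be assigned to a single change.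

The unmeasured compound 4 `COc1ccc(SC)c(NCC2=NCCN2)c1` differs from compound 1 in one place: methylsulfanyl in place of methylsulfonyl on an aromatic carbon. For the measured compounds named here, no measured step follows this change. Going by the values given here, the only single-place step at hand exchanges a different group and is within the scatter, so it says nothing about the sulfur group. Among the compounds with values here, the numbers of compound 1 and compound 3 show only that altering the sulfur group together with the methoxy shifts the number a great deal, leaving open how much belongs to the sulfur group alone. The estimated step is therefore a 4.3-fold higher number from compound 1 to compound 4 (0.63 log units; beyond the scatter), upward and uncertain. Compound 4 is expected to give 60 nM in this assay, within a range from 10 nM to 400 nM.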

Compound 4, half-maximal effective concentration: 1.59 nM
Compound 4: middle estimate off by 38-fold (1.58 log units), on the high side; the measured number lies below the stated range.
By their numbers in this assay, from the lowest: compound 4; then compounds 1 and 2 (each within the scatter of the next); then compound 3.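

Among the compounds shown here, this is the first step that changes the sulfur group alone, and it runs downward: in this assay, methylsulfanyl in place of methylsulfonyl on this aromatic carbon gives an 8.9-fold lower number from compound 1 to compound 4 (0.95 log units; beyond the scatter). So, with the rest of compound 1 unchanged, the methylsulfonyl group with its 4 heavy atoms and 2 double bonds is not required for the effect, since the methylsulfanyl group with 2 heavy atoms needs less compound to reach it. The earlier step at the methoxy position lay within the scatter, whereas this one lies beyond it, which marks the sulfur group as a place where a single change can move the number. Nothing at hand measures why removing the two oxygen atoms from the sulfur has this result.

Going by these compounds, two groups at one position cannot show a trend, so it remains open how the number would respond to a longer chain on the sulfur, as in ethylsulfanyl, or to a methylsulfinyl group or an amine at the same carbon. On these data alone, it is also open whether the same exchange would give a step of similar size with fluoro in place of the methoxy group.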